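Changing the Sulfonyl Aryl Group in a Cytotoxic Series

A few compounds are considered here, and "the series" means these few. Any claim that something is new, unique, unknown or untested is made for them only; others in the source may bear on it.

In a functional assay on LOX IMVI cells (Homo sapiens) for cytotoxicity, read by MTT assay, with a stated time of 24 h (on this read-out lower numbers stand for stronger inhibition and higher numbers for weaker inhibition), compound 1 (`COc1cc(-c2nc(-c3ccccc3)[nH]c2-c2ccnc(NCCCNS(=O)(=O)c3cccc4ccccc34)n2)ccc1F`) gives 14900 nM, compound 2 (`COc1cc(-c2nc(-c3ccccc3)[nH]c2-c2ccnc(NCCCNS(=O)(=O)c3ccc(F)cc3)n2)ccc1Cl`) gives 4530 nM, and compound 3 (`COc1cc(-c2nc(-c3ccccc3)[nH]c2-c2ccnc(NCCCNS(=O)(=O)c3ccc(C(F)(F)F)cc3)n2)ccc1Cl`) gives 1780 nM. Compound 3 therefore has the lowest number of the three. The next structure, compound 4 (`COc1cc(-c2nc(-c3ccccc3)[nH]c2-c2ccnc(NCCCNS(=O)(=O)c3cccc4ccccc34)n2)ccc1Cl`), departs from compound 3 at one place: naphthalen-1-yl in place of 4-(trifluoromethyl)phenyl on a sulfonyl sulfur. Among the measured compounds shown here, no measured pair makes this exact exchange of naphthalen-1-yl for 4-(trifluoromethyl)phenyl. For the measured compounds named here, the only measured single change is a 2.5-fold lower number from compound 2 to compound 3 (0.41 log units; beyond the scatter), where trifluoromethyl replaces fluoro on an aromatic carbon. That step is modest but beyond the scatter, and it shows that this assay can respond to a change in this part of the series. Compound 1 also carries naphthalen-1-yl on a sulfonyl sulfur, and its 14900 nM is a higher number than that of compound 3. However, compound 1 also differs from compound 4 elsewhere, so it is only a loose guide to the size of the change. On this limited evidence, a modest move towards a higher number is expected, a 2.5-fold higher number from compound 3 to compound 4 (0.40 log units; beyond the scatter). For compound 4 the estimate is 4500 nM, with an expected range of 1600 nM to 13000 nM.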

Compound 4, half-maximal inhibitory concentration: 13500 nM
Compound 4: middle estimate off by 3.0-fold (0.48 log units), on the low side, and the stated range ends below it.
By their numbers in this assay, from the lowest: compound 3; then compound 2; then compounds 4 and 1 (each within the scatter of the next).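

In this assay, among the compounds shown here, this exchange on a sulfonyl sulfur moves the number further than the one earlier step did: a 7.6-fold higher number from compound 3 to compound 4 (0.88 log units; beyond the scatter) is a larger step than a 2.5-fold lower number from compound 2 to compound 3 (0.41 log units; beyond the scatter), even though naphthalen-1-yl and 4-(trifluoromethyl)phenyl have the same count of heavy atoms. The new compound also places 4-fluorophenyl in the middle, since a 3.0-fold higher number from compound 2 to compound 4 (0.47 log units; beyond the scatter) lies beyond the scatter, so with chloro on the aromatic ring of the shared core the three sulfonyl aryl groups are separated, with 4-(trifluoromethyl)phenyl giving the lowest number and naphthalen-1-yl the highest. With naphthalen-1-yl on the sulfonyl sulfur, chloro in place of fluoro on an aromatic carbon makes no readable difference, as a 1.1-fold lower number from compound 1 to compound 4 (0.04 log units; within the scatter) stays within the scatter.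

Nothing given here explains why these aryl groups differ in this way. Going by these compounds, what remains open is whether an amine or a carboxylic acid in place of the trifluoromethyl on the phenyl ring, or a longer chain in place of the one carrying the sulfonamide, would take the number below that of compound 3 at 1780 nM in this assay or raise it.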